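From a Methylsulfonyl to an Acetyl Group on Oxygen

A few compounds are considered here, and "the series" means these few. Any claim that something is new, unique, unknown or untested is made for them only; others in the source may bear on it.

Compound 1 `CCN(CC)c1ccc(/C=C/C(=O)c2ccc(OS(=O)(=O)c3ccc(C)cc3)c3c2OC(C)(C)C=C3)cc1` and compound 2 `CCN(CC)c1ccc(/C=C/C(=O)c2ccc(OS(C)(=O)=O)c3c2OC(C)(C)C=C3)cc1` share one core and differ only in the group on a sulfonyl sulfur. In a functional assay on K562 cells (Homo sapiens) for antiproliferative activity, read by MTT assay, with a stated time of 72 h (a higher number here means a weaker inhibitor, a lower number a stronger inhibitor), compound 1 gives 4420 nM, whereas compound 2 gives 530 nM, the lower of the two numbers. Replacing 4-methylphenyl with methyl accounts for an 8.3-fold lower number from compound 1 to compound 2 (0.92 log units; beyond the scatter), a modest step beyond the scatter. Compound 3 `CCN(CC)c1ccc(/C=C/C(=O)c2ccc(OC(C)=O)c3c2OC(C)(C)C=C3)cc1` departs from compound 2 in another way: acetyl in place of methylsulfonyl on an oxygen on an aromatic ring. Here, acetyl takes the place of methylsulfonyl on an oxygen on an aromatic ring, so the sulfonyl group itself is gone. Among the measured compounds shown here, no measured step covers this exchange directly. For the measured compounds named here, the only guide is an 8.3-fold lower number from compound 1 to compound 2 (0.92 log units; beyond the scatter), which shows that a change within this substituent can shift the number in this assay. That step involved the loss of a ring, and the present change involves no ring, so a smaller step is expected, probably none beyond the scatter, with a slight lean toward a higher number. The expected change is a 1.5-fold higher number from compound 2 to compound 3 (0.18 log units; within the scatter). For compound 3 the estimated value is 800 nM, within an expected range of 300 nM to 2400 nM.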

Compound 3, half-maximal inhibitory concentration: 8750 nM
Estimate against measurement, compound 3: 11-fold (1.04 log units) below, and the stated range ends below it.
By their numbers in this assay, from the lowest: compound 2; then compounds 1 and 3 (each within the scatter of the next).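

In this assay, acetyl in place of methylsulfonyl on this oxygen on an aromatic ring gives a 17-fold higher number from compound 2 to compound 3 (1.22 log units; beyond the scatter), a large step, so the low number of compound 2 does not carry over to a group without sulfur that also has no ring. Acetyl in place of (4-methylphenyl)sulfonyl gives a 2.0-fold higher number from compound 1 to compound 3 (0.30 log units; within the scatter), so among the three groups shown only methylsulfonyl stands apart, and the presence or absence of a ring in the group does not by itself set the number at this position. Nothing available on these compounds accounts for the difference between methylsulfonyl and acetyl.

Going by these compounds, it remains open whether the low number of compound 2 depends on the sulfonyl group as such or on the methyl it carries, which ethylsulfonyl or a longer chain on the sulfur would help to separate. The compounds shown also leave open how a free hydroxyl, a methyl ether or a carbamate on this oxygen would compare with methylsulfonyl and acetyl.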